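The compounds below may be only part of what the source reports. "The series", "measured", "known", "first", "only" and "open" are said of these compounds alone.

Three compounds sharing one core were tested in an assay on HeLa cells for inhibition of Kinesin-like protein KIF15 (Homo sapiens), read by microscopy, with stated times of 2 s and 20 s, tested at 750 nM; a higher number here means more inhibition at the concentration tested (going by the name of the read-out), a lower number less inhibition. Compound 1 `O=C1Nc2ccc(C(=O)c3ccco3)cc2/C1=C/c1cc(F)c(O)c(F)c1` gives 21%, compound 2 `O=C1Nc2ccc(C(=O)c3ccco3)cc2/C1=C/c1ccnc(Cl)c1` gives 15.8%, and compound 3 `O=C1Nc2ccc(C(=O)c3ccco3)cc2/C1=C/c1ccc(O)c(C(F)(F)F)c1` gives 9.5%. Going by the values given here, the only single-point step measured, a number 5.2 percentage points lower from compound 1 to compound 2 (within the scatter), stays within the scatter. Compound 3 sits below compound 1 by more than the scatter, while its gap to compound 2 is within the scatter. Compound 4 `O=C1Nc2ccc(C(=O)c3ccco3)cc2/C1=C/c1ccc(O)c(Br)c1` is the next compound, differing from compound 3 by bromo in place of trifluoromethyl on an aromatic carbon. Among the compounds with values here, no measured step involves a bromo or a trifluoromethyl, so nothing here directly predicts this change. With only the flat step from compound 1 to compound 2 as a guide, compound 4 is expected to move by a number 2.5 percentage points higher from compound 3 to compound 4 (within the scatter), which is not beyond the scatter. Compound 4 is therefore estimated at 12%, in a range from 2% to 25%.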

Compound 4, a percentage reported as inhibition, at one concentration (the size of the read-out at that concentration, not a potency): 23%
Estimate against measurement, compound 4: 11 percentage points below, within the range that was stated.
By their numbers in this assay, from the lowest: compounds 3, 2, 1 and 4 (each within the scatter of the next, the first and the last beyond it).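

Bromo in place of trifluoromethyl, ortho to a hydroxy group, gives the first single-place change in this assay to clear the scatter: a number 13.5 percentage points higher from compound 3 to compound 4 (beyond the scatter). The other two steps, a number 7.2 percentage points higher from compound 2 to compound 4 (within the scatter) and a number 2 percentage points higher from compound 1 to compound 4 (within the scatter), leave 3-bromo-4-hydroxyphenyl indistinguishable from the groups of those two compounds. No measurement given here explains the step from trifluoromethyl to bromo. On these data alone, whether a methyl, a methoxy or an amine at this position would read like bromo or like trifluoromethyl stays open, as does what this change does without the neighbouring hydroxy group.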